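Compound 3 to compound 4: replacing the formyl group

This account rests on a few compounds, and the source may have more. Where it says the series, first, only, none or still open, it means among the compounds named here.

Measured in an ADME assay on HEK293 cells (Homo sapiens) for cytotoxicity, with a stated time of 72 h (a higher number here means that more compound is needed for the effect, a lower number that less compound is needed), each value being a limit of the assay:
- Compound 1 `C=C[C@@](C)(/C=C/c1ccc(O)cc1)CC/C=C(\C)CO` gives > 36600 nM 
- Compound 2 `C=C[C@@](C)(/C=C/c1ccc(O)cc1)CC/C=C(C)/C=C/C(=O)OCc1ccccc1` gives > 36600 nM 
- Compound 3 `C=C[C@@](C)(/C=C/c1ccc(O)c(C=O)c1)CCC=C(C)C` gives > 36600 nM 

Compound 3 gives only a limit and no number (see > 36600 nM). Among the compounds with values here, the whole series so far offers a single reading, (the limit of > 36600 nM in this assay, at which 3 of the 3 values shown sit), and no measured pair differs in one place. Compound 4 `C=C[C@@](C)(/C=C/c1ccc(O)c(/C=C(\C)C(=O)OCC)c1)CCC=C(C)C` carries 2-(ethoxycarbonyl)prop-1-en-1-yl in place of formyl on an aromatic carbon, ortho to a hydroxy group (2-(ethoxycarbonyl)prop-1-en-1-yl in place of formyl on an aromatic carbon). Within the data shown here, with no measured step to go by, no shift beyond the usual scatter is expected in this assay, and the estimated move is small (a step that the limit leaves unreadable from compound 3 to compound 4). For compound 4 the estimated value is 40000 nM (expected range 15000 nM to 100000 nM).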

Compound 4, half-maximal effective concentration: > 36600 nM
Compound 4 gave a limit, no number; the forecaster's own chance of this, stated with the estimate: 75%; the middle value lies beyond the limit too.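

Within the data shown here, compound 3 and compound 4 both give only a limit, so no step between them can be read. The compounds shown leave open whether replacing formyl shifts the concentration needed in this assay, since every reading is a limit: the limit of > 36600 nM in this assay, at which 4 of the 4 values shown sit.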